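A Second Chlorine on the Amide-Bound Ring

The compounds below may be only part of what the source reports. "The series", "measured", "known", "first", "only" and "open" are said of these compounds alone.

Compound 1, `O=C(CSc1nc(Nc2ccccc2)c2ccccc2n1)Nc1ccc(Cl)cc1`, in a functional assay on MGC-803 cells (Homo sapiens) for inhibition, read by MTT assay, with a stated time of 72 h; on this read-out lower numbers stand for stronger inhibition and higher numbers for weaker inhibition: 40400 nM
Compound 2, `O=C(CSc1nc(Nc2ccccc2)c2ccccc2n1)Nc1ccc(Br)cc1`, in this assay: 19300 nM

The two compounds share a core and differ only in the halogen on the phenyl ring attached to the amide nitrogen. Compound 2 holds the lowest of the two numbers in this assay. Within the data shown here, the single measured step is a 2.1-fold lower number from compound 1 to compound 2 (0.32 log units; beyond the scatter), a modest change from one halogen to another at that ring.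

Compound 3, `O=C(CSc1nc(Nc2ccccc2)c2ccccc2n1)Nc1ccc(Cl)c(Cl)c1`, is not yet measured. Relative to compound 2 the change is 3,4-dichlorophenyl in place of 4-bromophenyl on an amide-type nitrogen. Among the measured compounds shown here, the measured step bears on it only loosely: it shows that exchanging halogens on this ring shifted the number modestly, but no measured pair covers adding a second halogen. In this assay a modest step, or none beyond the scatter, is therefore expected. Compound 3 is estimated at 15000 nM, within 5000 nM to 45000 nM. That estimate corresponds to an expected step of a 1.3-fold lower number from compound 2 to compound 3 (0.11 log units; within the scatter).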

Compound 3, half-maximal inhibitory concentration: 37900 nM
Compound 3: middle estimate off by 2.5-fold (0.40 log units), on the low side, and the stated range covers the measured number.
By their numbers in this assay, from the lowest: compounds 2, 3 and 1 (each within the scatter of the next, the first and the last beyond it).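

Placing a second chlorine on the ring at the amide-type nitrogen, which turns 4-chlorophenyl into 3,4-dichlorophenyl, gives a 1.1-fold lower number from compound 1 to compound 3 (0.03 log units; within the scatter) in this assay, so this addition does not separate the two compounds. Exchanging 4-bromophenyl for 3,4-dichlorophenyl gives a 2.0-fold higher number from compound 2 to compound 3 (0.29 log units; within the scatter), so compound 3 cannot be told apart from either compound with one halogen, even though those two differ beyond the scatter. No measurement shown here accounts for these numbers.

The compounds shown leave open how the number would respond to a group on this ring other than a halogen, such as methoxy, an amine or a carboxylic acid. They also leave open what would happen if a longer alkyl chain took the place of the ring on the amide-type nitrogen.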